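Chloro to Fluoro in an Antiproliferative Pair

A few compounds are considered here, and "the series" means these few. Any claim that something is new, unique, unknown or untested is made for them only; others in the source may bear on it.

Compound 1 `O=C(NNc1ccc(F)cc1)c1ccccc1NS(=O)(=O)c1cnc(O)nc1O`: > 20000 nM (a limit)
Compound 2 `O=C(NNC(=O)c1ccccc1NS(=O)(=O)c1cnc(O)nc1O)c1ccccc1Cl`: 8310 nM

In a functional assay on MDA-MB-231 cells (Homo sapiens) for antiproliferative activity, read by MTT assay, with a stated time of 24 h (on this read-out lower numbers stand for stronger inhibition and higher numbers for weaker inhibition), compound 1 gives only a limit, > 20000 nM, as noted in the limit of > 20000 nM in this assay, at which 1 of the 2 values shown sits. Going by the values given here, compound 2, at 8310 nM, holds the only actual number so far. Compound 3 `O=C(NNC(=O)c1ccccc1NS(=O)(=O)c1cnc(O)nc1O)c1ccccc1F` differs from it by fluoro in place of chloro on an aromatic carbon, ortho to a large group. Among the compounds with values here, the one measured step, an at least 2.4-fold lower number from compound 1 to compound 2 (0.38 log units; beyond the scatter), exchanged 4-fluorophenyl for (2-chlorophenyl)carbonyl on an amine nitrogen and does not test this swap. No shift beyond the scatter is therefore expected in this assay. The expected change is a 1.2-fold higher number from compound 2 to compound 3 (0.08 log units; within the scatter). Compound 3 is estimated at 10000 nM, with a range of 4500 nM to 22000 nM.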

Compound 3, half-maximal inhibitory concentration: > 20000 nM
Compound 3 was reported as a limit (the forecaster's own chance of this, stated with the estimate: 20%); at least 2.0-fold (0.30 log units) between middle value and limit.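

In this assay, this position is not indifferent to the halogen: fluoro in place of chloro on an aromatic carbon, ortho to a large group, gives an at least 2.4-fold higher number from compound 2 to compound 3 (0.38 log units; beyond the scatter). Compound 3 gives only a limit, > 20000 nM. The step from compound 1 to compound 3 cannot be read, and the assay limit now holds most of the series: the limit of > 20000 nM in this assay, at which 2 of the 3 values shown sit.

The compounds shown leave open whether bromo or methyl in this place would retain the activity of compound 2. They also leave open how chloro would fare elsewhere on the ring.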